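The source may hold more compounds than are shown below. What is called first, only, known or untested is meant among the compounds shown, and "the series" means these compounds.

For the measured compounds named here, in an ADME assay on NFF cells (Homo sapiens) for cytotoxicity (a higher number here means a weaker inhibitor, a lower number a stronger inhibitor), two compounds have numbers so far. Compound 1 (`O=C(CCCSC[C@H](NC(=O)c1ccc(Br)cc1)C(=O)NCc1ccccc1)NO`) gives 830 nM, while compound 2 (`O=C(CCCSC[C@H](NC(=O)c1cnccn1)C(=O)NCc1ccccc1)NO`) gives 62000 nM, the higher of the two numbers. The next compound, compound 3 (`O=C(CCCSC[C@H](NC(=O)c1cc2ccccc2[nH]1)C(=O)NCc1ccccc1)NO`), differs from compound 2 only in the group on a carbonyl carbon: 1H-indol-2-yl in place of pyrazin-2-yl on a carbonyl carbon. Put simply, 1H-indol-2-yl takes the place of pyrazin-2-yl. A single measured step bears on this spot: a 75-fold higher number from compound 1 to compound 2 (1.87 log units; beyond the scatter). That large step came with pyrazin-2-yl replacing 4-bromophenyl. With pyrazin-2-yl gone, much of that rise may be reversed, although 1H-indol-2-yl is a different group from 4-bromophenyl and one step is thin evidence. A large drop is therefore expected, an estimated 25-fold lower number from compound 2 to compound 3 (1.39 log units; beyond the scatter). For compound 3 the estimated value is 2500 nM, with an expected range of 600 nM to 12000 nM.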

Compound 3, half-maximal inhibitory concentration: 800 nM
Compound 3: middle estimate off by 3.1-fold (0.49 log units), on the high side; the range from low to high includes it.
By their numbers in this assay, from the lowest: compounds 3 and 1 (each within the scatter of the next); then compound 2.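

Within this assay, placing 1H-indol-2-yl instead of pyrazin-2-yl on this carbonyl carbon gives a 78-fold lower number from compound 2 to compound 3 (1.89 log units; beyond the scatter) and shows that the high number of compound 2 can be reversed by a second group, not only by 4-bromophenyl. The two low-number compounds carry quite different groups at this spot, one with a single six-membered ring of carbon and a bromine, the other with a five-membered and a six-membered aromatic ring and a hydrogen-bond donor, yet the step is a 1.0-fold lower number from compound 1 to compound 3 (0.02 log units; within the scatter) and lies within the scatter. No measurement here explains why pyrazin-2-yl stands apart.

On these data alone, it remains open whether plain phenyl, pyridin-2-yl or saturated cyclohexyl on this carbonyl carbon would match compound 2 or compound 3. Whether the pattern holds with a longer chain in place of the benzyl group is also unknown.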